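Lengthening the hydroxycarbamoyl chain of compound 2

The source may hold more compounds than are shown below. What is called first, only, known or untested is meant among the compounds shown, and "the series" means these compounds.

In a functional assay on SK-HEP1 cells (Homo sapiens) for inhibition, read by sulforhodamine B assay, with a stated time of 48 h (on this read-out lower numbers stand for stronger inhibition and higher numbers for weaker inhibition), compound 1 (`O=C(Nc1ccc(Nc2ncc(C(=O)NO)cn2)cc1)Nc1ccc(Cl)c(C(F)(F)F)c1`) gives > 10000 nM as a limit of the assay and not a number. Compound 2 (`O=C(CCCCC(=O)Nc1ccc(NC(=O)Nc2ccc(Cl)c(C(F)(F)F)c2)cc1)NO`) gives > 10000 nM as a limit too. Compound 2 thus offers no number to start from, only the limit of > 10000 nM in this assay, at which 2 of the 2 values shown sit, and nothing finer. Compound 3 (`O=C(CCCCCCC(=O)Nc1ccc(NC(=O)Nc2ccc(Cl)c(C(F)(F)F)c2)cc1)NO`) differs from compound 2 by 2-(hydroxycarbamoyl)ethyl in place of hydroxycarbamoyl on a saturated chain carbon, four bonds along the chain from a carbonyl carbon with 2-(hydroxycarbamoyl)ethyl in place of hydroxycarbamoyl on a saturated chain carbon, four bonds along the chain from a carbonyl carbon. Among the measured compounds shown here, the one measured step is a step that the two limits leave unreadable from compound 1 to compound 2 and it concerns another change, so it lends no size here. No direction in this assay follows from it, and only a small gain, if any, is expected. The expected step is an at least 1.2-fold lower number from compound 2 to compound 3 (0.09 log units; that floor lies within the scatter) and it remains a rough estimate. Compound 3 is estimated at 8000 nM with an expected range from 2000 nM to 30000 nM and may well report only a limit again.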

Compound 3, half-maximal inhibitory concentration: 8100 nM
Beside the measured number, compound 3's estimate is 1.0-fold (0.01 log units) below it; the measured number falls inside the stated range.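

In this assay, the change to 2-(hydroxycarbamoyl)ethyl in place of hydroxycarbamoyl on a saturated chain carbon, four bonds along the chain from a carbonyl carbon, is read as an at least 1.2-fold lower number from compound 2 to compound 3 (0.09 log units; that floor lies within the scatter). That step is only a floor, so this position may tolerate the longer chain with little gain or with a larger one, and the data do not separate the two. Compound 3 is the only compound shown that gives a number, while the other two stay at a limit of the assay and not a number: the limit of > 10000 nM in this assay, at which 2 of the 3 values shown sit.

From the compounds shown here alone, it remains open how far the true gap extends and whether a longer chain ending in hydroxycarbamoyl would lower the number further. Also open, going by these compounds, is whether a carboxylic acid in place of the hydroxycarbamoyl would keep any inhibition on this chain.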